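The compounds below may be only part of what the source reports. "The series", "measured", "known", "first", "only" and "open" are said of these compounds alone.

Among the measured compounds shown here, compound 3 `Cc1ccc(S(=O)(=O)N2CC[C@@H](Br)C[C@@H]2CC(C)C)cc1` holds the only number in the set: in a functional assay on A2780 cells (Homo sapiens) for antiproliferative activity, read by sulforhodamine B assay, with a stated time of 48 h (on this read-out lower numbers stand for stronger inhibition of growth and higher numbers for weaker inhibition of growth), compound 3 gives 39000 nM. Compound 2 `Cc1ccc(S(=O)(=O)N2CCC(Br)CC2)cc1` sits at a limit of the assay, compound 2 giving > 100000 nM. Compound 1 `CCCCCCC[C@H]1C[C@H](Cl)CCN1S(=O)(=O)c1ccc(C)cc1` likewise sits at a limit, compound 1 giving > 100000 nM. For the measured compounds named here, the single measured step is an at least 2.5-fold lower number from compound 2 to compound 3 (0.40 log units; beyond the scatter). Compound 4 `CCCCCCC[C@H]1C[C@H](Br)CCN1S(=O)(=O)c1ccc(C)cc1` carries hexyl in place of isopropyl on a saturated chain carbon bound to a saturated ring carbon. No measured step covers a chain change of this kind, and an at least 2.5-fold lower number from compound 2 to compound 3 (0.40 log units; beyond the scatter) concerns a different substitution, so the steps shown give no direction; with two of three values resting at the limit (the limit of > 100000 nM in this assay, at which 2 of the 3 values shown sit), a number near that of compound 3 or a limit are both plausible outcomes. Compound 4 is estimated at 60000 nM, between 20000 nM and 200000 nM, an expected step of a 1.5-fold higher number from compound 3 to compound 4 (0.19 log units; within the scatter) within the scatter.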

Compound 4, concentration for 50% growth inhibition: > 100000 nM
Compound 4 was reported as a limit (the forecaster's own chance of this, stated with the estimate: 40%); middle value at least 1.6-fold (0.22 log units) from the limit.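

On the saturated chain carbon bound to a saturated ring carbon, hexyl in place of isopropyl gives an at least 2.5-fold higher number from compound 3 to compound 4 (0.40 log units; beyond the scatter), so the longer chain does not retain the activity of compound 3 in this assay. The gain from adding isobutyl therefore does not extend to this longer chain. The value of compound 4 is a limit, and the steps to it from compound 1 and compound 2 cannot be read, leaving most of the set at one boundary: the limit of > 100000 nM in this assay, at which 3 of the 4 values shown sit.

Open, from the compounds shown here alone, is whether a shorter chain such as ethyl, or a chain ending in an amine, would give a lower number at this place.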